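A few compounds are considered here, and "the series" means these few. Any claim that something is new, unique, unknown or untested is made for them only; others in the source may bear on it.

Series notes on cytotoxicity. Compound 2 `O=[N+]([O-])c1ccc(-c2nc3cc(C(F)(F)F)ccc3[nH]2)cc1` is the reference point. Going by the values given here, in an ADME assay on Vero cells (Chlorocebus sabaeus) for cytotoxicity (on this read-out higher numbers stand for lower toxicity in this test and lower numbers for higher toxicity in this test), compound 2 gives 45000 nM, the only plain number among the three results so far. Compound 3 `CCC(=O)Nc1ccc(-c2nc3cc(C(F)(F)F)ccc3[nH]2)cc1` sits at a limit of the assay in this assay, > 100000 nM. Compound 1 `CCC(=O)Nc1ccc(-c2nc3cc(C(F)(F)F)ccc3n2C2CCCCC2)cc1` likewise sits at a limit in this assay, > 100000 nM. This is the limit of > 100000 nM in this assay, at which 2 of the 3 values shown sit. One readable step is an at least 2.2-fold higher number from compound 2 to compound 3 (0.34 log units; beyond the scatter). The other step, the same exchange on the aromatic nitrogen as the one now in question but run in the reverse direction, is a step that the two limits leave unreadable from compound 1 to compound 3, with a limit at each end and no size to read.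

Compound 4 `O=[N+]([O-])c1ccc(-c2nc3cc(C(F)(F)F)ccc3n2C2CCCCC2)cc1` is the compound still to be measured. It differs from compound 2 by cyclohexyl in place of hydrogen on an aromatic nitrogen. Among the compounds with values here, the only measured step that bears on this exchange is the one between compound 1 and compound 3, and it gives no size, so no step beyond the scatter is expected in this assay. The estimated result for compound 4 in this assay is 60000 nM, with a range from 25000 nM to 150000 nM. The expected step is therefore a 1.3-fold higher number from compound 2 to compound 4 (0.12 log units; within the scatter), within the scatter.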

Compound 4, half-maximal cytotoxic concentration: > 100000 nM
Compound 4 was reported as a limit (the forecaster's own chance of this, stated with the estimate: 40%); middle value at least 1.6-fold (0.22 log units) from the limit.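

In this assay, the exchange on the aromatic nitrogen now has a readable size, with cyclohexyl in place of hydrogen giving an at least 2.2-fold higher number from compound 2 to compound 4 (0.34 log units; beyond the scatter). The value of compound 4, > 100000 nM, is a limit of the assay. The steps from compound 1 to compound 3 and from compound 1 to compound 4 cannot be read, and most of the series now rests on a single limit: the limit of > 100000 nM in this assay, at which 3 of the 4 values shown sit.

From the compounds shown here alone, how far compound 4 lies past its limit stays open, as does whether nitro and propanoylamino differ once cyclohexyl is present. Also open, going by these compounds, is whether methyl, or a longer chain ending in an amine, on the same aromatic nitrogen would give a number higher than that of compound 2 45000 nM.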